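The compounds below may be only part of what the source reports. "The series", "measured", "known", "first", "only" and "open" are said of these compounds alone.

All three compounds with numbers so far were tested in a functional assay on Vas deferens for antagonist activity at Alpha-1A adrenergic receptor (Rattus norvegicus); on this read-out higher numbers stand for higher potency (the scale is a negative logarithm) and lower numbers for lower potency:

compound 1, `COc1cccc(OC)c1OCCNCCOc1ccccc1OCc1ccccc1`, gives 8.39
compound 2, `COc1cccc(OC)c1OCCNCCOc1ccccc1OCc1ccccc1Cl`, gives 8.56
compound 3, `COc1cccc(OC)c1OCCNCCOc1ccccc1OCc1ccc(Cl)cc1`, gives 8.17

Compound 3 holds the lowest of the three numbers in this assay. Its nearest neighbour is compound 1, and the step of a number 0.22 log units lower from compound 1 to compound 3 (within the scatter) stays within the scatter, so these two cannot be ordered. The step of a number 0.39 log units lower from compound 2 to compound 3 (beyond the scatter) lies beyond the scatter and marks the one clear difference among the three.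

Compound 4, `COc1cccc(OC)c1OCCNCCOc1ccccc1OCc1ccccc1C`, differs from compound 3 in a single place: 2-methylphenyl in place of 4-chlorophenyl on a saturated chain carbon bound to an oxygen on an aromatic ring. Within the data shown here, two measured steps bear on this. The step of a number 0.17 log units higher from compound 1 to compound 2 (within the scatter) shows that placing a chloro on the aromatic carbon of the benzyl group as in compound 2 changed little, while the step of a number 0.39 log units lower from compound 2 to compound 3 (beyond the scatter) shows that moving the chloro to the position found in compound 3 cost a modest amount. Among the measured compounds shown here, a methyl in the position of compound 2 is untested, so the expectation is only that compound 4 recovers part of that modest loss: a step of a number 0.28 log units higher from compound 3 to compound 4 (within the scatter) is expected, not beyond the scatter with confidence. Compound 4 is therefore estimated at 8.45, in a range from 8.1 to 8.8.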

Compound 4, negative logarithm of the antagonist equilibrium constant: 7.81
The estimate for compound 4 lay 0.64 log units above the measured number, outside the stated range (below it).
By their numbers in this assay, from the lowest: compound 4; then compounds 3, 1 and 2 (each within the scatter of the next, the first and the last beyond it).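

In this assay, among these compounds, the 2-methylphenyl group is the first change on this saturated chain carbon to separate clearly from the plain benzyl of the parent, giving a number 0.58 log units lower from compound 1 to compound 4 (beyond the scatter), whereas neither chlorophenyl group did so. Exchanging only the chloro for a methyl on the aromatic carbon gives a number 0.75 log units lower from compound 2 to compound 4 (beyond the scatter), so at this place chloro and methyl are not interchangeable, and the 2-substituted pair holds both the highest and the lowest numbers of the series. Even the 4-chlorophenyl group, which held the lowest number until now, ends up clearly higher than 2-methylphenyl, with the swap giving a number 0.36 log units lower from compound 3 to compound 4 (beyond the scatter).

Nothing available explains why methyl and chloro part ways here. Still open, from the compounds shown here alone, is whether a fluoro, a bromo or a methoxy group on this aromatic carbon would follow the chloro of compound 2 or the methyl of compound 4, and whether 4-methylphenyl would stand closer to 4-chlorophenyl or to 2-methylphenyl.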